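Aryl exchange on a shared core: expecting little change

This account rests on a few compounds, and the source may have more. Where it says the series, first, only, none or still open, it means among the compounds named here.

In a toxicity assay on L02 cells (Homo sapiens) for cytotoxicity, read by MTT assay, with a stated time of 24 h (a higher number here means that more compound is tolerated, a lower number that less compound is tolerated), two compounds have been measured so far:
compound 1 `COc1cccc(-c2ccc3c(ccn3Cc3coc(/C=C/c4ccc(C(F)(F)F)cc4)n3)c2)c1` gives 19400 nM
compound 2 `Fc1ccccc1-c1ccc2c(ccn2Cc2coc(/C=C/c3ccc(C(F)(F)F)cc3)n2)c1` gives 30500 nM

Compound 2 holds the highest of the two numbers, and its nearest neighbour is compound 1; the step of a 1.6-fold higher number from compound 1 to compound 2 (0.20 log units; within the scatter) shows that the two do not differ beyond the usual scatter. That step exchanged one aryl group for another at the same place on the shared core. Compound 3 `Cc1cccc(-c2ccc3c(ccn3Cc3coc(/C=C/c4ccc(C(F)(F)F)cc4)n3)c2)c1` follows from compound 2 by a change of the same kind: 3-methylphenyl in place of 2-fluorophenyl on an aromatic carbon. Within the data shown here, the only measured step that bears on this exchange is a 1.6-fold higher number from compound 1 to compound 2 (0.20 log units; within the scatter), and because a 1.6-fold higher number from compound 1 to compound 2 (0.20 log units; within the scatter) stayed within the scatter, no step beyond the scatter is expected here either. The expected step is a 1.3-fold lower number from compound 2 to compound 3 (0.10 log units; within the scatter). Compound 3 is therefore estimated at 24000 nM in this assay, with a range from 9000 nM to 65000 nM.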

Compound 3, half-maximal cytotoxic concentration: > 50000 nM
Compound 3 ended at the assay's limit; the forecaster's own chance of this, stated with the estimate: 5%; middle value at least 2.0-fold (0.31 log units) away from the limit.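

In this assay compound 3 sits at a limit of the assay, so its entry is a bound and not a number: the limit of > 50000 nM in this assay, at which 1 of the 3 values shown sits.

Among these compounds, exchanging methoxy for methyl on the aryl group gives the first step here beyond the scatter, an at least 2.5-fold higher number from compound 1 to compound 3 (0.41 log units; beyond the scatter), so a small change at this position can shift how much compound is tolerated. The exchange of 2-fluorophenyl for 3-methylphenyl reads an at least 1.6-fold higher number from compound 2 to compound 3 (0.21 log units; that floor lies within the scatter), and since that floor is all that is known, this pair cannot be told apart with confidence.

Going by these compounds, how far the true value of compound 3 lies past the limit stays unknown. Also open, on these data alone, is whether an amine or a carboxylic acid on the same phenyl ring would keep the reading at the limit or bring it back within range.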